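Ring methylation on the cyclobutane core and its cost

The compounds below may be only part of what the source reports. "The series", "measured", "known", "first", "only" and "open" are said of these compounds alone.

Compound 2 `O[C@H](c1ccccn1)[C@]1(c2cccc(OC(F)(F)F)c2)C[C@H](O)C1` gives 40 nM in an assay on HEK293 cells for antagonist activity at transient receptor potential cation channel subfamily V member 3 (Homo sapiens), read by FLIPR and calcium flux; a lower number here means a stronger inhibitor, a higher number a weaker inhibitor. Compound 1 `C[C@]1(O)C[C@](c2cccc(OC(F)(F)F)c2)([C@H](O)c2ccccn2)C1` carries the change methyl in place of hydrogen on a saturated ring carbon and gives 1310 nM in this assay, a step of a 33-fold higher number from compound 2 to compound 1 (1.52 log units; beyond the scatter). Compound 3 `O[C@H](c1ccccn1)[C@]1(c2ccc(C(F)(F)F)cc2)C[C@H](O)C1` rests on a different core; the difference between the two cores is not broken down here. In this assay compound 3 gives 2240 nM. Compound 4 `C[C@]1(O)C[C@](c2ccc(C(F)(F)F)cc2)([C@H](O)c2ccccn2)C1` is not yet measured; it differs from compound 3 by methyl in place of hydrogen on a saturated ring carbon, the same change as that from compound 2 to compound 1, made at the same place on the ring. For the measured compounds named here, for compound 4 a step of a 13-fold higher number from compound 3 to compound 4 (1.13 log units; beyond the scatter) is expected, resting on the single earlier step of a 33-fold higher number from compound 2 to compound 1 (1.52 log units; beyond the scatter) and on the value of compound 3, 2240 nM. Going by the values given here, the estimate for compound 4 in this assay is 30000 nM, within the range 6000 nM to 150000 nM; with only one precedent this rests on little.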

Compound 4, antagonist equilibrium constant: 4790 nM
Beside the measured number, compound 4's estimate is 6.3-fold (0.80 log units) above it, outside the stated range (below it).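

Methyl in place of hydrogen on a saturated ring carbon raises the number on both cores in this assay, but the size of the step does not carry over from one core to the other: the same change on two cores in this assay, a 33-fold higher number (1.52 log units; beyond the scatter) from compound 2 to compound 1 and a 2.1-fold higher number (0.33 log units; beyond the scatter) from compound 3 to compound 4, 15-fold (1.19 log units) apart, beyond the scatter of two such steps On the core of compound 3 the change gives a 2.1-fold higher number from compound 3 to compound 4 (0.33 log units; beyond the scatter), so the direction is shared by the two pairs while the earlier size is not a usable guide. The two pairs do not show which difference between the cores sets the size of the step, and they give no rule for any third core.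

Open, from the compounds shown here alone, is how an ethyl group or an amine at the same ring carbon would behave on either core. Also open, going by these compounds, is whether a third core would follow either of the two steps.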